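Moving the trifluoromethyl group on the anilide ring

A few compounds are considered here, and "the series" means these few. Any claim that something is new, unique, unknown or untested is made for them only; others in the source may bear on it.

Measured in an ADME assay on MT4 cells (Homo sapiens) for cytotoxicity, read by MTT assay, with a stated time of 5 days; on this read-out lower numbers stand for higher toxicity in this test and higher numbers for lower toxicity in this test:
Compound 1 `COc1cc2nc([S+]([O-])CC(=O)Nc3cccc(Cl)c3)nc(Nc3c(Cl)cc(/C=C/C#N)cc3Cl)c2cc1OC`: 68900 nM
Compound 2 `COc1cc2nc([S+]([O-])CC(=O)Nc3ccccc3C(F)(F)F)nc(Nc3c(Cl)cc(/C=C/C#N)cc3Cl)c2cc1OC`: > 192000 nM

For compound 2 the reading of > 192000 nM is a limit and not a number. Compound 3 `COc1cc2nc([S+]([O-])CC(=O)Nc3ccc(C(F)(F)F)cc3)nc(Nc3c(Cl)cc(/C=C/C#N)cc3Cl)c2cc1OC` carries 4-(trifluoromethyl)phenyl in place of 2-(trifluoromethyl)phenyl on an amide-type nitrogen. Among the measured compounds shown here, one measured step bears on this place: an at least 2.7-fold higher number from compound 1 to compound 2 (0.44 log units; beyond the scatter). That step lies beyond the scatter, so the group on this nitrogen can shift the read-out, but it exchanged 3-chlorophenyl and did not test the new group. For the measured compounds named here, the only actual number to lean on is that of compound 1, at 68900 nM. The expected change is an at least 1.9-fold lower number from compound 2 to compound 3 (0.28 log units; that floor lies within the scatter), a modest move to a lower number, though this assay may again return only a limit. Compound 3 is estimated at 100000 nM, with an expected range of 40000 nM to 192000 nM.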

Compound 3, half-maximal cytotoxic concentration: 22000 nM
Beside the measured number, compound 3's estimate is 4.5-fold (0.66 log units) above it, outside the stated range (below it).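

In this assay the place of the trifluoromethyl group on the anilide ring matters in its own right: with the same atoms joined differently, the read-out shows an at least 8.7-fold lower number from compound 2 to compound 3 (0.94 log units; beyond the scatter) and no other part of the structure changes. The 4-(trifluoromethyl)phenyl group also reads lower than 3-chlorophenyl on the same amide-type nitrogen, with a 3.1-fold lower number from compound 1 to compound 3 (0.50 log units; beyond the scatter) in this assay, so a change at this nitrogen can move the number in either direction. The reading of compound 2 is a limit and not a number: the limit of > 192000 nM in this assay, at which 1 of the 3 values shown sits.

The compounds shown leave open whether an amine or a carboxylic acid in place of the trifluoromethyl group would keep the number high or lower it further. They also do not say why moving this group changes the read-out.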